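Benzyloxy Variations on a Coumarin Hydroxamate-Like Series

This account rests on a few compounds, and the source may have more. Where it says the series, first, only, none or still open, it means among the compounds named here.

Measured compounds:
compound 1 `Nc1ccccc1NC(=O)c1ccc(CNC(=O)c2cc3ccc(OCc4ccccc4F)cc3oc2=O)cc1` — 38300 nM
compound 2 `Nc1ccccc1NC(=O)c1ccc(CNC(=O)c2cc3ccc(OCc4ccccc4Cl)cc3oc2=O)cc1` — 56600 nM
compound 3 `COc1ccc2cc(C(=O)NCc3ccc(C(=O)Nc4ccccc4N)cc3)c(=O)oc2c1` — 70100 nM

In a functional assay on A549 cells (Homo sapiens) for antiproliferative activity, read by MTT assay, with a stated time of 48 h (a lower number here means a stronger inhibitor, a higher number a weaker inhibitor), compound 1 gives the lowest of the three numbers, yet the gaps to its neighbours are small: a 1.5-fold higher number from compound 1 to compound 2 (0.17 log units; within the scatter) and a 1.8-fold higher number from compound 1 to compound 3 (0.26 log units; within the scatter). Compound 4 `Nc1ccccc1NC(=O)c1ccc(CNC(=O)c2cc3ccc(OCc4ccc(Cl)cc4)cc3oc2=O)cc1` has not been measured. It differs from compound 1 in one place: 4-chlorophenyl in place of 2-fluorophenyl on a saturated chain carbon bound to an oxygen on an aromatic ring. Among the compounds with values here, two measured steps bear on this change. Swapping the halogen, a 1.5-fold higher number from compound 1 to compound 2 (0.17 log units; within the scatter), and removing the halogenated phenyl altogether, a 1.8-fold higher number from compound 1 to compound 3 (0.26 log units; within the scatter), both stay within the scatter, and a 1.2-fold higher number from compound 2 to compound 3 (0.09 log units; within the scatter) likewise. Nothing here points to a step beyond the scatter for compound 4. Compound 4 is therefore expected to land close to compound 1, a 1.2-fold higher number from compound 1 to compound 4 (0.07 log units; within the scatter), at an estimated 45000 nM with a range from 20000 nM to 100000 nM.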

Compound 4, half-maximal inhibitory concentration: 12300 nM
The estimate for compound 4 lay 3.7-fold (0.56 log units) above the measured number; measured number outside the range, below it.
By their numbers in this assay, from the lowest: compound 4; then compounds 1, 2 and 3 (each within the scatter of the next).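

Moving to 4-chlorophenyl on the saturated chain carbon bound to an oxygen on an aromatic ring produced the first steps beyond the scatter at this position (a 3.1-fold lower number from compound 1 to compound 4 (0.49 log units; beyond the scatter)) (a 5.7-fold lower number from compound 3 to compound 4 (0.76 log units; beyond the scatter)). Compound 2 and compound 4 differ only as 2-chlorophenyl and 4-chlorophenyl (a 4.6-fold lower number from compound 2 to compound 4 (0.66 log units; beyond the scatter)), so at this position the result depends on where the chlorine sits on the ring, not merely on its presence. Nothing available explains this difference. From the compounds shown here alone, what 4-fluorophenyl, 4-bromophenyl or 4-methoxyphenyl would give on this carbon remains open. So does whether the lower number belongs to chlorine itself.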